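This account rests on a few compounds, and the source may have more. Where it says the series, first, only, none or still open, it means among the compounds named here.

The study measured two compounds in an ADME assay on Vero cells (Chlorocebus sabaeus) for cytotoxicity, with a stated time of 72 h, tested at 50 ug/mL (on this read-out lower numbers stand for a weaker effect and higher numbers for a stronger effect at the one concentration tested), and this account follows the change from the first of them to a third compound that has not yet been measured. Compound 1 `N=c1c(=O)[nH]nc2n1CCN2c1ccccc1Cl` carries a chloro group on a six-membered aromatic ring of carbon only; in this assay compound 1 gives 2%. Compound 2 `N/N=C1\NCCN1c1ccccc1` is built on a different framework, and in this assay compound 2 gives 0%. On the numbers shown, compound 1 cannot be set apart from compound 2: the two read-outs lie within the usual scatter of each other, and both show hardly any effect at the single concentration tested. Compound 3 `N=c1c(=O)[nH]nc2n1CCN2c1ccccc1` differs from compound 1 in one place: hydrogen in place of chloro on an aromatic carbon. Among the measured compounds shown here, no step between measured compounds exists for this change, so there is nothing to lean on beyond the fact that compound 1 sits at the floor of the read-out. With both measured numbers near zero, the step from compound 1 to compound 3 is expected to be none beyond the scatter, no change at the digits printed from compound 1 to compound 3 (within the scatter). Compound 3 is therefore estimated at 2%, within a range from -5% to 10%.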

Compound 3, a percentage reported as inhibition, at one concentration (the size of the read-out at that concentration, not a potency): 30%
Compound 3: middle estimate off by 28 percentage points, on the low side, and the stated range ends below it.
By their numbers in this assay, from the lowest: compounds 2 and 1 (each within the scatter of the next); then compound 3.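

In this assay, hydrogen in place of chloro on an aromatic carbon, ortho to a large group, gives a number 28 percentage points higher from compound 1 to compound 3 (beyond the scatter), so this position on the six-membered aromatic ring of carbon only does register in the read-out, which the earlier pair, built on different frameworks, could not show. The low reading of compound 1 therefore does not hold for every compound on its core: with the same core and no chloro, compound 3 gives 30%. Nothing shown here gives a measured reason for this step.

The compounds shown hold only chloro and hydrogen on this carbon, so it remains open whether a fluoro, methyl or methoxy group there would read like chloro, like hydrogen or somewhere else. As far as these compounds go, it also remains open whether the step belongs to this one carbon or would recur with chloro on another carbon of the same ring, and, with a single concentration tested, how the two compounds would compare across a range of concentrations.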